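Shifting the Methyl on the Phenoxy Arm

A few compounds are considered here, and "the series" means these few. Any claim that something is new, unique, unknown or untested is made for them only; others in the source may bear on it.

Compound 3 `Cc1ccccc1OCC(=O)Nc1nc(-c2ccc(Cl)cc2)cs1` carries a 2-methylphenoxy group on one side of the shared core and a chloro-substituted aryl on the other. In a functional assay on MDA-MB-468 cells (Homo sapiens) for cytotoxicity, read by MTT assay, with a stated time of 48 h (on this read-out higher numbers stand for weaker inhibition and lower numbers for stronger inhibition), compound 3 gives 40100 nM. Its two measured companions differ from it only at the aryl attached to the core: compound 1 `Cc1ccc(-c2csc(NC(=O)COc3ccccc3C)n2)cc1`, with a methyl there, gives 52100 nM, and compound 2 `Cc1ccccc1OCC(=O)Nc1nc(-c2ccc(Br)cc2)cs1`, with a bromo, gives 44900 nM. The steps of a 1.2-fold lower number from compound 1 to compound 2 (0.06 log units; within the scatter), a 1.3-fold lower number from compound 1 to compound 3 (0.11 log units; within the scatter) and a 1.1-fold lower number from compound 2 to compound 3 (0.05 log units; within the scatter) all stay within the scatter, so compound 3 has the lowest of the three numbers without being separable from either neighbour.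

Compound 4 `Cc1ccc(OCC(=O)Nc2nc(-c3ccc(Cl)cc3)cs2)cc1` alters a different part of the molecule: 4-methylphenyl in place of 2-methylphenyl on an oxygen on a saturated carbon. None of the three measured steps touches this position; each exchanged a group on the other aryl, and each was small. There is thus no measured step that bears directly on the change from compound 3 to compound 4, and the small steps seen elsewhere give no reason to expect a large one here. The expected step in this assay is therefore a 1.0-fold lower number from compound 3 to compound 4 (0.00 log units; within the scatter), with no direction beyond the scatter. For compound 4 the estimated value in this assay is 40000 nM, within a range from 15000 nM to 110000 nM.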

Compound 4, half-maximal inhibitory concentration: 50900 nM
Compound 4: the middle estimate sits 1.3-fold (0.10 log units) below what was measured; the range from low to high includes it.
By their numbers in this assay, from the lowest: compounds 3, 2, 4 and 1 (each within the scatter of the next).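

Among the compounds shown here, the first step at the phenoxy arm reads a 1.3-fold higher number from compound 3 to compound 4 (0.10 log units; within the scatter) and so stays within the scatter in this assay: with the chloro-substituted aryl held fixed, compound 3 and compound 4 cannot be told apart. For the compounds shown here, the earlier steps all exchanged a group on the other aryl while keeping 2-methylphenyl, so only this pair shows that 2-methylphenoxy and 4-methylphenoxy give values that are not separable here, and all four compounds now lie within the scatter of their neighbours in the ranking. Nothing available on these compounds speaks to why the two isomers read alike, and the result itself offers no explanation.

Because this exchange is seen only alongside the chloro-substituted aryl, the compounds shown leave open whether 4-methylphenyl would read the same alongside the methyl or bromo aryl of compound 1 and compound 2. They also leave open whether a different group on the phenoxy ring, such as an amine, a carboxylic acid or a longer alkyl chain in place of the methyl, would move the number beyond the scatter.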